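Changing the group on the sulfonyl sulfur of compound 3

This account rests on a few compounds, and the source may have more. Where it says the series, first, only, none or still open, it means among the compounds named here.

In a functional assay on CWR22R cells (Homo sapiens) for antiproliferative activity, read by propidium iodide staining, with a stated time of 96 h (on this read-out higher numbers stand for weaker inhibition and lower numbers for stronger inhibition), compound 3 `CC(O)(CS(=O)(=O)c1ccc(C(F)(F)F)cc1)C(=O)Nc1ccc(S(F)(F)(F)(F)F)cc1` stands at 28900 nM and lies within the scatter of both compound 1 `CC(O)(COc1ccc(C#N)cc1)C(=O)Nc1cccc(S(F)(F)(F)(F)F)c1` at 32500 nM and compound 2 `CC(O)(CS(=O)(=O)c1ccc(S(F)(F)(F)(F)F)cc1)C(=O)Nc1ccc(S(F)(F)(F)(F)F)cc1` at 17300 nM alike. Compound 4 `CC(O)(CS(=O)(=O)c1ccccc1OC(F)(F)F)C(=O)Nc1ccc(S(F)(F)(F)(F)F)cc1` carries 2-(trifluoromethoxy)phenyl in place of 4-(trifluoromethyl)phenyl on a sulfonyl sulfur with the rest unchanged. Within the data shown here, one measured step bears on this group, a 1.7-fold higher number from compound 2 to compound 3 (0.22 log units; within the scatter) and it does not cover the entering group, so the evidence is thin. The expected step is a 1.2-fold lower number from compound 3 to compound 4 (0.06 log units; within the scatter) in this assay and none beyond the scatter is anticipated. The estimate for compound 4 is 25000 nM with an expected range from 10000 nM to 55000 nM.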

Compound 4, half-maximal inhibitory concentration: 16000 nM
Estimate against measurement, compound 4: 1.6-fold (0.19 log units) above, and the stated range covers the measured number.
By their numbers in this assay, from the lowest: compounds 4, 2, 3 and 1 (each within the scatter of the next, the first and the last beyond it).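

A step of a 1.8-fold lower number from compound 3 to compound 4 (0.26 log units; within the scatter) follows in this assay when 2-(trifluoromethoxy)phenyl replaces 4-(trifluoromethyl)phenyl on the sulfonyl sulfur. Among these compounds, the earlier step exchanged only one group on an aromatic carbon, whereas this one replaces the whole group on the sulfonyl sulfur, and the number still stays within the scatter. Nothing measured here explains this step. On these data alone, whether an amine or a carboxylic acid on that phenyl ring, or a plain alkyl chain in its place, would move the number beyond the scatter remains open.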